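Chloro to Methoxy: A Small Change on a Shared Core

The source may report more compounds than this note shows. Statements on the series, on what has been measured and on what is new or still open speak of the compounds shown alone.

Of the compounds shown here, three built on one shared core have been tested in a functional assay on Jurkat cells (Homo sapiens) for activation, with a stated time of 24 h; a lower number here means that less compound is needed, a higher number that more compound is needed for the effect. Compound 1 `Oc1ccccc1CNc1ccc(N2CCCC2)cc1` gives "not active" (no number reported) in this assay. Compound 2 `Cc1ccc(-c2ccc(NCc3ccccc3O)cc2)cc1` gives 3790 nM, and compound 3 `Oc1ccccc1CNc1ccc(-c2cccc(Cl)c2)cc1` gives 6200 nM. Within the data shown here, compound 3 thus carries the higher of the two reported numbers, but its only neighbour is compound 2, and the step of a 1.6-fold higher number from compound 2 to compound 3 (0.21 log units; within the scatter) lies within the scatter, so the two cannot be told apart on these data.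

Compound 4 `COc1cccc(-c2ccc(NCc3ccccc3O)cc2)c1` has not yet been measured. It differs from compound 3 by methoxy in place of chloro on an aromatic carbon. Among the measured compounds shown here, no measured step exchanges exactly these two groups. For the measured compounds named here, the one step that bears on the question, a 1.6-fold higher number from compound 2 to compound 3 (0.21 log units; within the scatter), swapped the group at this same place and stayed within the scatter, which suggests that such swaps move the number little. The step expected from this change is therefore a 1.2-fold lower number from compound 3 to compound 4 (0.09 log units; within the scatter), nothing beyond the scatter. Compound 4 is estimated at 5000 nM in this assay, with a range from 1800 nM to 14000 nM.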

Compound 4, half-maximal effective concentration: "not active" (no number reported)
Nothing numeric was reported for compound 4; no gap can be computed for the estimate.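

Among these compounds, with compound 4 at "not active" (no number reported) in this assay and compound 3 giving a number, no step between the two can be read. Nothing shown here explains this result. Still open is why methoxy in place of chloro separates compound 4 from compound 3.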